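Chloro for methoxy on a second chalcone core

The source may hold more compounds than are shown below. What is called first, only, known or untested is meant among the compounds shown, and "the series" means these compounds.

Of the compounds shown here, three have been measured in a functional assay on RPMI8266 cells (Homo sapiens) for inhibition; a higher number here means a weaker inhibitor of growth, a lower number a stronger inhibitor of growth. Compound 3 `COc1ccc(-c2cn(-c3cccc(C(=O)/C=C/c4cc(OC)c(OC)c(OC)c4)c3)c(=O)[nH]2)cc1` gives 920 nM, and compound 1 `COc1cc(/C=C/C(=O)c2cccc(-n3cc(-c4ccc(Cl)cc4)[nH]c3=O)c2)cc(OC)c1OC` gives 3920 nM; the change between them is chloro in place of methoxy on an aromatic carbon, and it made a 4.3-fold higher number from compound 3 to compound 1 (0.63 log units; beyond the scatter). Compound 2 `COc1ccc(-c2cn(-c3cccc(C(=O)/C=C/c4ccc(O)c(OC)c4)c3)c(=O)[nH]2)cc1` gives 1350 nM; its core differs from that of compound 3 by 4-hydroxy-3-methoxyphenyl in place of 3,4,5-trimethoxyphenyl on a double-bonded chain carbon bound to a double-bonded chain carbon, and a 1.5-fold lower number from compound 2 to compound 3 (0.17 log units; within the scatter). Compound 4 `COc1cc(/C=C/C(=O)c2cccc(-n3cc(-c4ccc(Cl)cc4)[nH]c3=O)c2)ccc1O` is not yet measured. It differs from compound 2 by chloro in place of methoxy on an aromatic carbon, the same change that leads from compound 3 to compound 1. On the second core the step is expected to be of similar size, a 3.7-fold higher number from compound 2 to compound 4 (0.57 log units; beyond the scatter), because compound 1 showed a 4.3-fold higher number from compound 3 to compound 1 (0.63 log units; beyond the scatter) after the same change. Compound 4 is therefore estimated at 5000 nM, expected between 2000 nM and 14000 nM.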

Compound 4, concentration for 50% growth inhibition: 1330 nM
Estimate against measurement, compound 4: 3.8-fold (0.58 log units) above; measured number outside the range, below it.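

In this assay, 4-chlorophenyl in place of 4-methoxyphenyl gave a 1.0-fold lower number from compound 2 to compound 4 (0.01 log units; within the scatter), so on this core the change left the two compounds within the scatter of each other. Set beside the earlier step, the change did not carry over unaltered from one core to the other: the same change on two cores in this assay, a 4.3-fold higher number (0.63 log units; beyond the scatter) from compound 3 to compound 1 and a 1.0-fold lower number (0.01 log units; within the scatter) from compound 2 to compound 4, 4.3-fold (0.64 log units) apart, beyond the scatter of two such steps. With a single pair on each core, this shows that the size of the step depended on the core in these compounds, but it does not show which feature of the cores is responsible or how the change would behave on a further core.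

The compounds shown leave open whether other groups in the same place, such as fluoro, methyl or an amine, would follow the step seen on one core or the other. They also leave open how the change would behave with a carboxylic acid on the phenyl ring at the far end of the double bond.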